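The source may report more compounds than this note shows. Statements on the series, on what has been measured and on what is new or still open speak of the compounds shown alone.

Working notes on the series. Among the measured compounds shown here, compound 3 `CCc1ccc(C(=O)/C=C/c2ccc3c(c2)B(O)OC3)cc1` gives 20600 nM in a toxicity assay on WI-38 cells (Homo sapiens) for cytotoxicity, read by MTT assay, with a stated time of 48 h (on this read-out higher numbers stand for weaker inhibition and lower numbers for stronger inhibition), the lowest of the three numbers so far, although compound 2 `O=C(/C=C/c1ccc2c(c1)B(O)OC2)c1ccc(Cl)cc1` with 24700 nM sits within the scatter of it, and only compound 1 `O=C(/C=C/c1ccc2c(c1)B(O)OC2)c1ccco1` with 59000 nM lies clearly higher. The two measured steps are a 2.4-fold lower number from compound 1 to compound 2 (0.38 log units; beyond the scatter) and a 1.2-fold lower number from compound 2 to compound 3 (0.08 log units; within the scatter). Compound 4 `O=C(/C=C/c1ccc2c(c1)B(O)OC2)c1ccc(O)cc1` differs from compound 3 by hydroxy in place of ethyl on an aromatic carbon. For the measured compounds named here, the one step at this aromatic carbon, a 1.2-fold lower number from compound 2 to compound 3 (0.08 log units; within the scatter), stayed within the scatter, and no step introducing a hydroxy is known, so the expected step is a 1.5-fold higher number from compound 3 to compound 4 (0.16 log units; within the scatter), with no clear direction beyond the scatter. Compound 4 is therefore estimated at 30000 nM in this assay, with a range from 12000 nM to 80000 nM.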

Compound 4, half-maximal inhibitory concentration: > 100000 nM
Compound 4: only a limit was reported; the forecaster's own chance of this, stated with the estimate: 10%; middle value at least 3.3-fold (0.52 log units) from the limit.
By their numbers in this assay, from the lowest: compounds 3 and 2 (each within the scatter of the next); then compound 1. At a limit, above all of these: compound 4.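

Among the compounds shown here, at this aromatic carbon, where chloro and ethyl stayed within the scatter of each other, hydroxy is the first group to shift the number clearly in this assay, with an at least 4.8-fold higher number from compound 3 to compound 4 (0.68 log units; beyond the scatter) and an at least 4.0-fold higher number from compound 2 to compound 4 (0.60 log units; beyond the scatter). Against the furan-2-yl of compound 1 the change is less clear, with an at least 1.6-fold higher number from compound 1 to compound 4 (0.22 log units; that floor lies within the scatter). Compound 4 is reported only as a limit, so the full size of these steps cannot be read: the limit of > 100000 nM in this assay, at which 1 of the 4 values shown sits.

Still open, from the compounds shown here alone, is whether hydroxy stands alone here, or whether an amine, a methoxy group or a carboxylic acid on this carbon would also raise the number.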